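A Bromophenyl Carbamoyl Variant on a Shared Core

This account rests on a few compounds, and the source may have more. Where it says the series, first, only, none or still open, it means among the compounds named here.

In a functional assay on HL-60 cells (Homo sapiens) for cytotoxicity, read by MTT assay, with a stated time of 24 h (a higher number here means a weaker inhibitor, a lower number a stronger inhibitor), compound 1 `CCCCn1cc(Cn2nc(N)c3c(C(F)(F)F)cc(-c4ccccc4)nc32)nn1` gives 36.7 ug/mL, the highest of the three numbers shown, though compound 3 `Nc1nn(Cc2cn(CC(=O)Nc3c(F)cccc3F)nn2)c2nc(-c3ccccc3)cc(C(F)(F)F)c12` at 32.8 ug/mL and compound 2 `CCCCCCCCCCn1cc(Cn2nc(N)c3c(C(F)(F)F)cc(-c4ccccc4)nc32)nn1` at 29.9 ug/mL both sit within the scatter of it. Compound 4 `Nc1nn(Cc2cn(CC(=O)Nc3ccccc3Br)nn2)c2nc(-c3ccccc3)cc(C(F)(F)F)c12` differs from compound 1 by (2-bromophenyl)carbamoyl in place of propyl on a saturated chain carbon bound to an aromatic nitrogen. The closest precedents are the steps of a 1.1-fold lower number from compound 1 to compound 3 (0.05 log units; within the scatter) and a 1.1-fold higher number from compound 2 to compound 3 (0.04 log units; within the scatter), both within the scatter, and the chain extension a 1.2-fold lower number from compound 1 to compound 2 (0.09 log units; within the scatter) was likewise flat. The move to the bromophenyl carbamoyl group is therefore expected to bring no shift beyond the scatter, an expected step of a 1.1-fold lower number from compound 1 to compound 4 (0.05 log units; within the scatter). Compound 4 is estimated at 33 ug/mL, with an expected range from 20 ug/mL to 55 ug/mL.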

Compound 4, half-maximal inhibitory concentration: 27.2 ug/mL
Estimate against measurement, compound 4: 1.2-fold (0.08 log units) above; the measured number falls inside the stated range.
By their numbers in this assay, from the lowest: compounds 4, 2, 3 and 1 (each within the scatter of the next).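

In this assay, among these compounds, the change on the amide-type nitrogen, 2-bromophenyl in place of 2,6-difluorophenyl, is the first step here made on the aryl ring itself, and it stays within the scatter (a 1.2-fold lower number from compound 3 to compound 4 (0.08 log units; within the scatter)). The comparisons with the alkyl chains stay there too (a 1.3-fold lower number from compound 1 to compound 4 (0.13 log units; within the scatter)) and (a 1.1-fold lower number from compound 2 to compound 4 (0.04 log units; within the scatter)), so this position has tolerated butyl, decyl and both halogenated aryl carbamoyl groups without a readable difference. As far as these compounds go, whether an unsubstituted phenyl carbamoyl, a carboxylic acid or an amine at this position would move the number remains open. No evidence is available that bears on this result.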